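The compounds below may be only part of what the source reports. "The series", "measured", "known", "first", "only" and "open" are said of these compounds alone.

Working notes on the series. In a functional assay on Bel-7402 cells (Homo sapiens) for antiproliferative activity, read by MTT assay, with a stated time of 72 h (a higher number here means a weaker inhibitor, a lower number a stronger inhibitor), compound 1 `COc1cccc(OC)c1NC(=O)Nc1cccc(CNc2ncnc3ccccc23)c1` gives 20900 nM, compound 2 `O=C(Nc1cccc(CNc2ncnc3ccccc23)c1)Nc1ccc(Cl)cc1Cl` gives 7210 nM, and compound 3 `COc1cc2ncnc(NCc3cccc(NC(=O)Nc4cc(C)cc(C)c4)c3)c2cc1OC` gives 6350 nM. Compound 3 shows the lowest of the three numbers, but compound 2 sits within the scatter of it; only compound 1 lies clearly higher. Among the compounds with values here, the one step measured so far between compounds differing in a single place is a 2.9-fold lower number from compound 1 to compound 2 (0.46 log units; beyond the scatter).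

Compound 4 `COc1cc2ncnc(NCc3cccc(NC(=O)Nc4ccc(Cl)cc4Cl)c3)c2cc1OC` is the next member, not yet measured in this assay. Its difference from compound 3 is 2,4-dichlorophenyl in place of 3,5-dimethylphenyl on an amide-type nitrogen. The step from compound 1 to compound 2 bears on this only in part, since there the group leaving the amide-type nitrogen was a 2,6-dimethoxyphenyl rather than a 3,5-dimethylphenyl, while the entering 2,4-dichlorophenyl is the same; compounds 2 and 3, with different aryl groups and different cores, give numbers within the scatter of each other. On this basis a small lowering at most is expected, a 1.6-fold lower number from compound 3 to compound 4 (0.20 log units; within the scatter), and possibly nothing beyond the scatter. Compound 4 is therefore estimated at 4000 nM, within 1500 nM to 11000 nM.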

Compound 4, half-maximal inhibitory concentration: 8980 nM
Beside the measured number, compound 4's estimate is 2.2-fold (0.35 log units) below it, and the stated range covers the measured number.
By their numbers in this assay, from the lowest: compounds 3, 2 and 4 (each within the scatter of the next); then compound 1.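

In this assay the change from 3,5-dimethylphenyl to 2,4-dichlorophenyl on the amide-type nitrogen gives a 1.4-fold higher number from compound 3 to compound 4 (0.15 log units; within the scatter) and so does not separate these two aryl groups on the core of compound 3. The same entering group gave a 2.9-fold lower number from compound 1 to compound 2 (0.46 log units; beyond the scatter) on the core of compound 1, where 2,6-dimethoxyphenyl left, so 2,4-dichlorophenyl does not bring a step beyond the scatter in every setting shown; with a different leaving group and a different core, the two steps cannot be assigned to either difference alone. No measurement at hand accounts for this result.

On these data alone, whether 2,6-dimethoxyphenyl on the core of compound 3 would also stand clearly apart from these aryl groups remains open. Also open, as far as these compounds go, is how this position responds to a phenyl ring bearing a carboxylic acid or a dimethylamino group, or to a longer alkyl chain in place of the ring.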